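The source may report more compounds than this note shows. Statements on the series, on what has been measured and on what is new or still open speak of the compounds shown alone.

Compound 1 `O=C(/C=C/c1ccco1)c1ccc(NC(=O)c2cccs2)cc1`: 56000 nM
Compound 2 `CC(=O)Nc1ccc(C(=O)/C=C/c2cccc([N+](=O)[O-])c2)cc1`: 6300 nM
Compound 3 `O=C(/C=C/c1cccc([N+](=O)[O-])c1)c1ccc(NC(=O)c2ccco2)cc1`: 22000 nM

In a functional assay on DLD-1 cells (Homo sapiens) for cytotoxicity, read by resazurin assay, with a stated time of 48 h (on this read-out lower numbers stand for an effect already at smaller amounts and higher numbers for an effect only at larger amounts of compound), compound 3 stands second highest of the three numbers, above compound 2 and below compound 1. The next compound, compound 4 `O=C(/C=C/c1cccc([N+](=O)[O-])c1)c1ccc(NC(=O)c2cccs2)cc1`, differs from compound 3 by thiophen-2-yl in place of furan-2-yl on a carbonyl carbon. Within the data shown here, no measured step covers this exchange. Among the measured compounds shown here, the only step at the same carbonyl carbon is a 3.5-fold higher number from compound 2 to compound 3 (0.54 log units; beyond the scatter), which exchanges methyl for a five-membered aromatic ring rather than one such ring for another. Compound 1 carries thiophen-2-yl on that carbonyl carbon but differs from compound 3 elsewhere as well, so the two values show no isolated effect of the ring. For the measured compounds named here, with no direct precedent, the expected step of a 1.1-fold lower number from compound 3 to compound 4 (0.04 log units; within the scatter) is none beyond the scatter. Compound 4 is estimated at 20000 nM, within 8000 nM to 50000 nM.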

Compound 4, half-maximal effective concentration: 11000 nM
Compound 4: middle estimate off by 1.8-fold (0.26 log units), on the high side; measured number inside the range.
By their numbers in this assay, from the lowest: compounds 2, 4 and 3 (each within the scatter of the next, the first and the last beyond it); then compound 1.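

In this assay, thiophen-2-yl in place of furan-2-yl on the carbonyl carbon gives a 2.0-fold lower number from compound 3 to compound 4 (0.30 log units; within the scatter), so the two five-membered aromatic rings are not separated at this position. Thiophen-2-yl in place of methyl there gives a 1.7-fold higher number from compound 2 to compound 4 (0.24 log units; within the scatter), while furan-2-yl in place of methyl gave a 3.5-fold higher number from compound 2 to compound 3 (0.54 log units; beyond the scatter) and so is the only one of these two exchanges to leave the scatter. Among these compounds, with thiophen-2-yl held on the carbonyl carbon, 3-nitrophenyl in place of furan-2-yl on the double-bonded chain carbon gives a 5.1-fold lower number from compound 1 to compound 4 (0.71 log units; beyond the scatter) as the first isolated step at that place, and nothing available explains these steps.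

Open, on these data alone, is how an amine or a longer alkyl chain on the carbonyl carbon would read, and whether the step at the double-bonded chain carbon holds with methyl or furan-2-yl on the carbonyl carbon.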